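Compound 3 trades 3-fluorophenyl for 4-cyclopropylphenyl

The compounds below may be only part of what the source reports. "The series", "measured", "known", "first", "only" and "open" are said of these compounds alone.

Compound 1 `O=C(NCCCCc1ccccc1)c1cccc(C2SCC(=O)N2c2cccc(-c3c[nH]nn3)c2)c1` gives 20000 nM here
Compound 2 `C#Cc1cccc(N2C(=O)CSC2c2cccc(C(=O)NCCCCc3ccccc3)c2)c1` gives 10000 nM here
Compound 3 `O=C(NCCCCc1ccccc1)c1cccc(C2SCC(=O)N2c2cccc(F)c2)c1` gives 10000 nM here

In a physicochemical assay for solubility, read by turbidimetry, measured as kinetic solubility, at pH 6.8 (a higher number here means a more soluble compound, a lower number a less soluble compound), compound 2 and compound 3 read the same at the digits shown, and compound 1 lies within the scatter of both. Compound 4 `O=C(NCCCCc1ccccc1)c1cccc(C2SCC(=O)N2c2ccc(C3CC3)cc2)c1` has not been measured yet. It differs from compound 3 on an amide-type nitrogen in a ring, where 4-cyclopropylphenyl comes in place of 3-fluorophenyl 4-cyclopropylphenyl in place of 3-fluorophenyl on an amide-type nitrogen in a ring while the rest of the molecule stays the same.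

The closest evidence comes from swaps of a group on an aromatic carbon of that same aromatic ring. Fluoro in place of 1H-1,2,3-triazol-4-yl gave a 2.0-fold lower number from compound 1 to compound 3 (0.30 log units; within the scatter) and fluoro in place of ethynyl gave no change at the digits printed from compound 2 to compound 3 (within the scatter) while ethynyl in place of 1H-1,2,3-triazol-4-yl gave a 2.0-fold lower number from compound 1 to compound 2 (0.30 log units; within the scatter) in the same series. None of these compounds carries a cyclopropyl group, so the evidence is indirect. The estimate means an expected 1.3-fold lower number from compound 3 to compound 4 (0.10 log units; within the scatter) in this assay with no step beyond the scatter and no firm direction. For compound 4 the estimated value is 8000 nM and the expected range runs from 3000 nM to 20000 nM on this measure.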

Compound 4, solubility: 2000 nM
Compound 4: middle estimate off by 4.0-fold (0.60 log units), on the high side; the measured number lies below the stated range.
By their numbers in this assay, from the lowest: compound 4; then compounds 2, 3 and 1 (each within the scatter of the next).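

Swaps among the groups on the phenyl ring of compounds 1, 2 and 3 all stayed within the scatter in this assay, but 4-cyclopropylphenyl on the amide-type nitrogen in a ring gives a 5.0-fold lower number from compound 3 to compound 4 (0.70 log units; beyond the scatter) and a 5.0-fold lower number from compound 2 to compound 4 (0.70 log units; beyond the scatter), the first steps here beyond it. The largest step, a 10-fold lower number from compound 1 to compound 4 (1.00 log units; beyond the scatter), shows that this position can move the number clearly, and downwards in this case. No measured evidence here accounts for the drop.

The group's name changes in both its substituent and its number. 3-cyclopropylphenyl or 4-fluorophenyl would be needed to tell whether the cyclopropyl group or its place on the ring matters. On these data alone, it also remains open how a phenyl ring bearing an amine or a carboxylic acid would read in this assay at this position.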